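Trimming the Sulfonamide Amine of Compound 1

The source may report more compounds than this note shows. Statements on the series, on what has been measured and on what is new or still open speak of the compounds shown alone.

Compound 1 `O=C([C@@H]1CCCN(S(=O)(=O)c2ccc(S(=O)(=O)N3CC[C@@H](O)C3)cc2)C1)N1CCC(F)(F)CC1` carries a difluoropiperidine amide and a hydroxypyrrolidinyl sulfonamide; in a functional assay on BXPC-3 cells (Homo sapiens) for inhibition, read by MTT assay, with a stated time of 7 days (a higher number here means a weaker inhibitor, a lower number a stronger inhibitor), compound 1 gives 330 nM, the lowest of the three numbers recorded so far. Compound 2 `CCN(CC)S(=O)(=O)c1ccc(S(=O)(=O)N2CCC[C@@H](C(=O)NC3COC3)C2)cc1` gives 13800 nM and compound 3 `CCN(CC)S(=O)(=O)c1ccc(S(=O)(=O)N2CCC[C@@H](C(=O)N[C@H]3CCOC3)C2)cc1` gives 5270 nM; both pair a diethylamino sulfonamide with a smaller amide, and both sit well beyond the scatter from compound 1. For the measured compounds named here, the only recorded step, a 2.6-fold lower number from compound 2 to compound 3 (0.42 log units; beyond the scatter), changes the amide alone and says nothing directly about the amine on the sulfonyl sulfur. Compound 4 `CN(C)S(=O)(=O)c1ccc(S(=O)(=O)N2CCC[C@@H](C(=O)N3CCC(F)(F)CC3)C2)cc1` keeps the amide of compound 1 and differs from it in one place: dimethylamino in place of 3-hydroxypyrrolidin-1-yl on a sulfonyl sulfur. Going by the values given here, no measured step bears on this exchange, so the expectation rests on compound 1 alone, and the step is expected to be modest rather than large, most likely toward a higher number. Compound 4 is therefore estimated at 800 nM, within 200 nM to 3200 nM, which would mean an expected step of a 2.4-fold higher number from compound 1 to compound 4 (0.38 log units; beyond the scatter).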

Compound 4, half-maximal inhibitory concentration: 560 nM
Estimate against measurement, compound 4: 1.4-fold (0.15 log units) above; the range from low to high includes it.
By their numbers in this assay, from the lowest: compounds 1 and 4 (each within the scatter of the next); then compound 3; then compound 2.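

In this assay, for the compounds shown here, replacing 3-hydroxypyrrolidin-1-yl with dimethylamino on a sulfonyl sulfur, with the amide of compound 1 held fixed, gives a 1.7-fold higher number from compound 1 to compound 4 (0.23 log units; within the scatter), the first direct reading at this position. The ring, the hydrogen-bond donor and acceptor and the defined stereocentre all leave with the 3-hydroxypyrrolidin-1-yl group, yet the two numbers stay within the scatter of each other, so none of these features is required for a value in this range. No measurement offered here bears on why the two compounds read alike.

Open, going by these compounds, is how morpholin-4-yl, or a longer chain ending in a carboxylic acid, would read on the same sulfonyl sulfur. Compound 2 and compound 3 differ from compound 4 in more than one place, so the separate contribution of the difluoropiperidine amide also remains unresolved.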